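Bromohydroxyphenyl in place of dimethoxyphenyl on the hydrazone

A few compounds are considered here, and "the series" means these few. Any claim that something is new, unique, unknown or untested is made for them only; others in the source may bear on it.

Two members of this series have been measured in a functional assay on U-87MG ATCC cells (Homo sapiens) for cytotoxicity, read by MTT assay, with a stated time of 72 h; on this read-out lower numbers stand for stronger inhibition and higher numbers for weaker inhibition. Compound 1 `COc1ccc(OC)c(/C=N/NC(=O)Nc2ccc(Oc3ccnc(-c4nncn4CCN(C)C)c3)c(F)c2)c1` gives 6400 nM in this assay. Among the compounds with values here, compound 2 `COc1ccc(/C=N/NC(=O)Nc2ccc(Oc3ccnc(-c4nncn4CCN(C)C)c3)c(F)c2)c(OC)c1` stands at 12600 nM; its only neighbour is compound 1, and the step of a 2.0-fold higher number from compound 1 to compound 2 (0.29 log units; within the scatter) lies within the scatter, so this assay does not separate the two. Compound 3 `CN(C)CCn1cnnc1-c1cc(Oc2ccc(NC(=O)N/N=C/c3ccc(O)c(Br)c3)cc2F)ccn1` has not yet been measured. It differs from compound 2 in one place: 3-bromo-4-hydroxyphenyl in place of 2,4-dimethoxyphenyl on a carbon with a double bond to nitrogen. Within the data shown here, no measured step bears on this exchange; the single step available, a 2.0-fold higher number from compound 1 to compound 2 (0.29 log units; within the scatter), swaps one dimethoxyphenyl for another on the same carbon and stays within the scatter. The data hold nothing on a hydroxy group or a bromine at this position, so no movement beyond the scatter can be foreseen in either direction. Compound 3 is therefore expected at an estimated 10000 nM, with a range from 3000 nM to 35000 nM. The step of a 1.3-fold lower number from compound 2 to compound 3 (0.10 log units; within the scatter) that this estimate means is expected to remain within the scatter.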

Compound 3, half-maximal inhibitory concentration: 12400 nM
Compound 3: middle estimate off by 1.2-fold (0.09 log units), on the low side, and the stated range covers the measured number.
By their numbers in this assay, from the lowest: compounds 1, 3 and 2 (each within the scatter of the next).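

In this assay, the exchange on the carbon with a double bond to nitrogen reads as a 1.0-fold lower number from compound 2 to compound 3 (0.01 log units; within the scatter) and as a 1.9-fold higher number from compound 1 to compound 3 (0.29 log units; within the scatter), so this assay separates 3-bromo-4-hydroxyphenyl from neither dimethoxyphenyl group. Within the data shown here, the earlier step swapped only one dimethoxyphenyl for another, whereas this change removes both methoxy groups and brings in a hydroxy group, a bromine and a hydrogen-bond donor that the dimethoxyphenyl groups lack, and still no step leaves the scatter. At this position, then, the three compounds show that a quite different substitution on the aromatic ring can be accommodated without a separable change in this read-out, although no measurement here offers an explanation for that.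

The hydroxy group and the bromine enter together, so the compounds shown leave open what either would do alone on the ring. They also leave open whether any group at this position, such as an amine, a carboxylic acid or a longer chain, would move the number beyond the scatter in either direction.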